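From Dimethylphenyl to Methoxyphenyl on the Shared Core

The source may hold more compounds than are shown below. What is called first, only, known or untested is meant among the compounds shown, and "the series" means these compounds.

In a functional assay on DU-145 cells (Homo sapiens) for inhibition, read by trypan blue exclusion, with a stated time of 96 h (a lower number here means a stronger inhibitor of growth, a higher number a weaker inhibitor of growth), compound 2 (`Cc1ccc(C)c(/C=C(\C(=O)c2ccc(Br)cc2)S(=O)(=O)Cc2ccc(F)cc2)c1`) gives 1000 nM, level with compound 3 (`Cc1ccc(S(=O)(=O)/C(=C/c2ccc(Cl)cc2)C(=O)c2ccc(Cl)cc2)cc1`) at 1000 nM. Together they hold the lowest of the three numbers, while compound 1 (`Cc1cc(C)cc(/C=C(\C(=O)c2ccc(Br)cc2)S(=O)(=O)Cc2ccc(F)cc2)c1`) gives 10000 nM. The next structure, compound 4 (`COc1ccccc1/C=C(\C(=O)c1ccc(Br)cc1)S(=O)(=O)Cc1ccc(F)cc1`), keeps the rest of compound 2 and changes one group: 2-methoxyphenyl in place of 2,5-dimethylphenyl on a double-bonded chain carbon bound to a double-bonded chain carbon. Going by the values given here, one measured step bears on this place: a 10-fold lower number from compound 1 to compound 2 (1.00 log units; beyond the scatter). It shows that this assay can respond strongly to a change in the group at this place, but it involves no 2-methoxyphenyl group. Compound 3 differs from compound 2 in more than one place and offers no direct comparison. Among the compounds with values here, with no measured precedent for the new group, only a small shift within the scatter is expected, and a larger one cannot be ruled out. The expected change is a 1.4-fold lower number from compound 2 to compound 4 (0.15 log units; within the scatter). For compound 4, the estimated value is 700 nM, with an expected range of 150 nM to 4000 nM.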

Compound 4, concentration for 50% growth inhibition: 25000 nM
The estimate for compound 4 lay 36-fold (1.55 log units) below the measured number; measured number outside the range, above it.
By their numbers in this assay, from the lowest: compounds 2 and 3 (each within the scatter of the next); then compound 1; then compound 4.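

The change at this place proved far from neutral: in this assay, a 25-fold higher number from compound 2 to compound 4 (1.40 log units; beyond the scatter), so 2-methoxyphenyl did not stand in for 2,5-dimethylphenyl on a double-bonded chain carbon bound to a double-bonded chain carbon. The new group also fell short of 3,5-dimethylphenyl, with a 2.5-fold higher number from compound 1 to compound 4 (0.40 log units; beyond the scatter), which puts the three groups in a clear order at this place, with 2,5-dimethylphenyl ahead of 3,5-dimethylphenyl and 2-methoxyphenyl last. No supporting evidence accounts for these differences.

The compounds shown leave open whether the drop belongs to the methoxy group or to the loss of a methyl group. A plain phenyl, a phenyl bearing a single methyl, a dimethoxyphenyl or an ethoxyphenyl group at this place could help separate those two readings.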